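The source may hold more compounds than are shown below. What is called first, only, known or untested is meant among the compounds shown, and "the series" means these compounds.

The series shares one core and varies the aryl group on the carbonyl carbon of the anilide. In a functional assay on GTL 16 cells for antiproliferative activity against GTL 16 cell line (Homo sapiens), read by CCK-8 assay, with a stated time of 72 h (on this read-out lower numbers stand for stronger inhibition and higher numbers for weaker inhibition), compound 1 `O=C(Nc1cccc(-c2oc3cc(-c4ccc(F)cc4)ccc3c(=O)c2O)c1)c1ccccc1F` gives 17400 nM. Compound 2 `COc1ccccc1C(=O)Nc1cccc(-c2oc3cc(-c4ccc(F)cc4)ccc3c(=O)c2O)c1` gives 6370 nM in this assay, and compound 3 `COc1cccc(C(=O)Nc2cccc(-c3oc4cc(-c5ccc(F)cc5)ccc4c(=O)c3O)c2)c1` gives 12500 nM. Compound 2 carries the lowest of the three numbers: the step of a 2.7-fold lower number from compound 1 to compound 2 (0.44 log units; beyond the scatter) lies beyond the scatter, whereas the step of a 2.0-fold higher number from compound 2 to compound 3 (0.29 log units; within the scatter) does not, so compound 2 and compound 3 cannot be told apart. The step of a 1.4-fold lower number from compound 1 to compound 3 (0.14 log units; within the scatter) is likewise within the scatter.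

Compound 4 `COc1cc(OC)cc(C(=O)Nc2cccc(-c3oc4cc(-c5ccc(F)cc5)ccc4c(=O)c3O)c2)c1` is not yet measured. Relative to compound 2 the change is 3,5-dimethoxyphenyl in place of 2-methoxyphenyl on a carbonyl carbon. Among the compounds with values here, the only measured step that touches this position of the methoxy group is a 2.0-fold higher number from compound 2 to compound 3 (0.29 log units; within the scatter), a small rise within the scatter; nothing measured speaks to a second methoxy group. The expectation for compound 4 is therefore a number near compound 3, and the step of a 1.9-fold higher number from compound 2 to compound 4 (0.28 log units; within the scatter) is expected to stay close to the scatter. Compound 4 is estimated at 12000 nM, with a range from 5000 nM to 30000 nM.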

Compound 4, half-maximal inhibitory concentration: 19600 nM
Beside the measured number, compound 4's estimate is 1.6-fold (0.21 log units) below it; low and high end bracket the measured number.
By their numbers in this assay, from the lowest: compounds 2, 3, 1 and 4 (each within the scatter of the next, the first and the last beyond it).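

The step of a 3.1-fold higher number from compound 2 to compound 4 (0.49 log units; beyond the scatter) clears the scatter, so in this assay the 3,5-dimethoxyphenyl group on the carbonyl carbon separates from the 2-methoxyphenyl group in a way the 3-methoxyphenyl group did not. The other two steps do not separate: a 1.6-fold higher number from compound 3 to compound 4 (0.20 log units; within the scatter) and a 1.1-fold higher number from compound 1 to compound 4 (0.05 log units; within the scatter) both stay within the scatter, so the second methoxy group cannot be read as having an effect of its own. No evidence on the cause of these steps is available here.

Still open, as far as these compounds go, is whether the 2-methoxyphenyl group truly differs from the 3-methoxyphenyl group, since that step stays within the scatter. Also open, from the compounds shown here alone, is how this assay would read an aryl group carrying an amine or a carboxylic acid, or a longer chain in place of the aryl group on the carbonyl carbon.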